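Adding a Chloro Group to a Bis-Chalcone Core

A few compounds are considered here, and "the series" means these few. Any claim that something is new, unique, unknown or untested is made for them only; others in the source may bear on it.

Compound 2 `Cc1cc(O)c(C(=O)/C=C/c2ccccc2)c(-c2ccccc2)c1C(=O)/C=C/c1ccccc1` and compound 1 `Cc1cc(O)c(C(=O)/C=C/c2ccccc2)c(-c2ccc(Cl)cc2)c1C(=O)/C=C/c1ccccc1` share one core and differ by chloro in place of hydrogen on an aromatic carbon. In a functional assay on MCF7 cells (Homo sapiens) for cytotoxicity, read by MTT assay, with a stated time of 24 h (a higher number here means a weaker inhibitor, a lower number a stronger inhibitor), compound 2 gives 10000 nM, and compound 1 gives 15000 nM, so the change made a step of a 1.5-fold higher number from compound 2 to compound 1 (0.18 log units; within the scatter). Compound 3 `Cc1cc(O)c(C(=O)/C=C/c2cccc3ccccc23)c(-c2ccccc2)c1C(=O)/C=C/c1cccc2ccccc12` rests on a different core, and how its core differs from that of compound 2 is not broken down here; in this assay compound 3 gives 30000 nM. Compound 4 `Cc1cc(O)c(C(=O)/C=C/c2cccc3ccccc23)c(-c2ccc(Cl)cc2)c1C(=O)/C=C/c1cccc2ccccc12` differs from compound 3 by chloro in place of hydrogen on an aromatic carbon, the same change as between compound 2 and compound 1. The expected step is a 1.5-fold higher number from compound 3 to compound 4 (0.18 log units; within the scatter), which rests on the earlier step of a 1.5-fold higher number from compound 2 to compound 1 (0.18 log units; within the scatter) being small. Compound 4 in this assay is therefore estimated at 45000 nM, with an expected range from 20000 nM to 100000 nM.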

Compound 4, half-maximal inhibitory concentration: 30000 nM
Compound 4: middle estimate off by 1.5-fold (0.18 log units), on the high side; the measured number falls inside the stated range.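

In this assay, putting chloro in place of hydrogen on the core of compound 3 gives no change at the digits printed from compound 3 to compound 4 (within the scatter), and the two cores agree on this change: the same change on two cores in this assay, a 1.5-fold higher number (0.18 log units; within the scatter) from compound 2 to compound 1 and no change at the digits printed (within the scatter) from compound 3 to compound 4, 1.5-fold (0.18 log units) apart, within the scatter of two such steps. On these two cores, then, going from phenyl to 4-chlorophenyl gives a step within the usual scatter, so a result seen on one core carried over to the other. Two pairs in a single cell assay do not show that this would hold on other cores or in other assays, and they do not explain the result.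

The compounds shown leave open whether an amine or a carboxylic acid on the same ring would give a step beyond the scatter. The same question stands for a longer chain there.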